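A few compounds are considered here, and "the series" means these few. Any claim that something is new, unique, unknown or untested is made for them only; others in the source may bear on it.

Measured so far:
compound 1 `CC[C@H](C)[C@H](NC(=O)CN(c1nc(Cl)nc2[nH]cnc12)C1CC1)C(=O)O` — 21.4%
compound 2 `NC(=O)C[C@H](NC(=O)CN(c1nc(Cl)nc2[nH]cnc12)C1CC1)C(=O)O` — 17%

In a functional assay on the whole organism (Tail, strain ICR) with Mus musculus as the target, in the tail flick test, with a stated time of 120 min, at a dose of 25 umol/kg by the oral route (a lower number here means a weaker effect, a higher number a stronger effect of the compound at the dose given), compound 1 gives 21.4%. Compound 2 gives 17% in this assay, and the step of a number 4.4 percentage points lower from compound 1 to compound 2 (within the scatter) keeps the two compounds within the scatter of each other, so on the numbers shown compound 1 is not separated from compound 2.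

Compound 3 `CC[C@H](C)[C@H](NC(=O)CN(c1nc(Cl)nc2[nH]cnc12)C1CC1)C(=O)OCc1ccccc1` is not yet measured. It differs from compound 1 by benzyl in place of hydrogen on an oxygen next to a carbonyl group. Among the measured compounds shown here, the one measured step, from compound 1 to compound 2, alters the sec-butyl group and leaves the oxygen next to the carbonyl untouched; it therefore gives no guide to this change, and it was itself within the scatter. For the measured compounds named here, no step in this assay beyond the scatter can be grounded for compound 3, and the expected step of a number 0.4 percentage points lower from compound 1 to compound 3 (within the scatter) is set close to zero. Compound 3 is estimated at 21%, with a range from 6% to 40%.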

Compound 3, a percentage reported as activity, at one dose (the size of the read-out at that dose, not a potency): 22%
For compound 3 the middle estimate is 1 percentage points below the measured one; the range from low to high includes it.
By their numbers in this assay, from the lowest: compounds 2, 1 and 3 (each within the scatter of the next).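

In this assay, among the compounds shown here, benzyl in place of hydrogen on an oxygen next to a carbonyl group gives a number 0.6 percentage points higher from compound 1 to compound 3 (within the scatter), the first reading at this position, as the earlier step touched only the sec-butyl group. Carboxy and benzyloxycarbonyl are therefore not separated at this dose and time, so on the sec-butyl compounds a free carboxy is not required for a read-out of this size. No measured information bears on this result.

Open, as far as these compounds go, is whether a smaller group on the same oxygen, such as methyl or ethyl, also stays within the scatter of compound 1. Also open, from the compounds shown here alone, is whether benzyl on this oxygen gives the same picture when carbamoylmethyl replaces sec-butyl, as in compound 2.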